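The source may report more compounds than this note shows. Statements on the series, on what has been measured and on what is new or still open speak of the compounds shown alone.

Measured so far:
- compound 1, `OCc1c(C(F)(F)F)nc2c(OCc3ccccc3)cccn12`, 2
- compound 2, `Cc1nc2c(OCc3ccccc3)cccn2c1CO`, 6.1
- compound 3, `Cc1nc2c(/C=C/c3ccccc3)cccn2c1C`, 7.2

In a physicochemical assay for acid dissociation, compound 1 stands lowest of the three numbers shown: compound 2 lies a number 4.10 log units higher from compound 1 to compound 2 (beyond the scatter), and compound 3 lies further still. Compound 1 and compound 2 differ in one place, methyl in place of trifluoromethyl on an aromatic carbon, and that single change carries the whole of the measured step between them. Compound 2 and compound 3 differ in more than one place, so their two values can only be read side by side: compound 2 gives 6.1, compound 3 gives 7.2.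

Compound 4, `Cc1c(C(F)(F)F)nc2c(OCc3ccccc3)cccn12`, comes from compound 1 by a different change: hydrogen in place of hydroxy on a saturated chain carbon bound to an aromatic carbon. Among the measured compounds shown here, nothing among the measured steps covers a change of this kind, since the only single step known concerns the trifluoromethyl group, which compound 4 keeps. Without a comparable step to lean on, the change is expected to move the number little, probably within or close to the scatter, with a slight upward lean. Compound 4 is therefore expected to come out near 2.4, between 1.6 and 3.2, which is an expected step of a number 0.40 log units higher from compound 1 to compound 4 (beyond the scatter).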

Compound 4, acid dissociation constant: 2
Compound 4: middle estimate off by 0.40 log units, on the high side, within the range that was stated.
By their numbers in this assay, from the lowest: compounds 1 and 4 (each within the scatter of the next); then compound 2; then compound 3.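

Replacing hydroxy with hydrogen on a saturated chain carbon bound to an aromatic carbon, the change from hydroxymethyl to methyl, gives no change at the digits printed from compound 1 to compound 4 (within the scatter) in this assay, so the trifluoromethyl compounds now show a measured result at this second position. Among the compounds shown here, until now the only single change on record was the one on the aromatic carbon, a number 4.10 log units higher from compound 1 to compound 2 (beyond the scatter), and with both changes starting from compound 1, only that one moves the number beyond the scatter. No supporting measurement is available to explain why removing the hydroxy group leaves the number within the scatter.

One question left open is whether the same swap would behave in the same way with methyl rather than trifluoromethyl on the aromatic carbon, since compound 2 and compound 3 differ in more than one place and their values can only be read side by side. It also remains open how the number would respond if an amine, a carboxylic acid or a longer chain stood in place of the hydroxy group on that chain carbon, as the compounds shown carry only hydroxy or hydrogen there.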